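Working notes: bromo for methyl in compound 1

The compounds below may be only part of what the source reports. "The series", "measured", "known", "first", "only" and "open" are said of these compounds alone.

compound 1 `Cc1cccc(NS(=O)(=O)c2ccc(N3CCNC3=O)cc2)c1` gives 1270 nM
compound 2 `COc1cc(NS(=O)(=O)c2ccc(N3CCNC3=O)cc2)cc(OC)c1OC` gives 45 nM

In a functional assay on MDA-MB-231 cells (Homo sapiens) for antiproliferative activity, read by sulforhodamine B assay, with a stated time of 48 h (a higher number here means a weaker inhibitor, a lower number a stronger inhibitor), compound 1 holds the higher of the two numbers and sits well above compound 2, a gap beyond the scatter. Compound 3 `O=C1NCCN1c1ccc(S(=O)(=O)Nc2cccc(Br)c2)cc1` keeps the core of compound 1 and changes in one place (bromo in place of methyl on an aromatic carbon): bromo in place of methyl on an aromatic carbon, meta to a large group, so that 3-methylphenyl becomes 3-bromophenyl. Within the data shown here, no measured pair isolates this exchange, so the data give no direct size or direction for it. No step beyond the scatter is therefore expected in this assay, and compound 3 is expected to stay near compound 1 (1270 nM). The expected change is a 1.3-fold lower number from compound 1 to compound 3 (0.10 log units; within the scatter) and would lie within the scatter. The estimate for compound 3 is 1000 nM with an expected range from 300 nM to 3500 nM on repeated measurement.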

Compound 3, half-maximal inhibitory concentration: 290 nM
Beside the measured number, compound 3's estimate is 3.4-fold (0.54 log units) above it, and the stated range ends above it.
By their numbers in this assay, from the lowest: compound 2; then compound 3; then compound 1.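

Among these compounds, the exchange of 3-methylphenyl for 3-bromophenyl is the only single-place step measured so far: in this assay, bromo in place of methyl gives a 4.4-fold lower number from compound 1 to compound 3 (0.64 log units; beyond the scatter). This aromatic position, meta to a large group, therefore responds to replacing one heavy atom with another, even though the counts of hydrogen-bond donors and acceptors do not change. No data at hand explain the step.

The compounds shown leave open whether chloro, trifluoromethyl or an amine in the same place would give a number nearer that of bromo or of methyl. They also leave open whether the same exchange would produce a similar step on a ring carrying further groups.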